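From a carbamoyl side chain to 3,5-difluorophenyl

This account rests on a few compounds, and the source may have more. Where it says the series, first, only, none or still open, it means among the compounds named here.

Measured in an ADME assay on MT4 cells (Homo sapiens) for cytotoxicity, read by MTT assay; on this read-out lower numbers stand for higher toxicity in this test and higher numbers for lower toxicity in this test:
- Compound 1 `Cc1cc(C)cc(S(=O)(=O)c2c(C(=O)NCc3cccc(F)c3F)[nH]c3ccc(Cl)cc23)c1`: > 51100 nM, a limit
- Compound 2 `Cc1cc(C)cc(S(=O)(=O)c2c(C(=O)NCC(=O)NCc3ccccc3F)[nH]c3ccc(Cl)cc23)c1`: > 47300 nM, a limit
- Compound 3 `Cc1cc(C)cc(S(=O)(=O)c2c(C(=O)NC(C)C(=O)NCc3ccccc3F)[nH]c3ccc(Cl)cc23)c1`: 23300 nM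

Going by the values given here, compound 3, at 23300 nM, holds the only actual number of the three. Compound 4 `Cc1cc(C)cc(S(=O)(=O)c2c(C(=O)NC(C)c3cc(F)cc(F)c3)[nH]c3ccc(Cl)cc23)c1` differs from it as follows: 3,5-difluorophenyl in place of (2-fluorobenzyl)carbamoyl on a saturated chain carbon bound to an amide-type nitrogen and a saturated chain carbon. Among the compounds with values here, two measured steps bear on this change. The closest in kind, a step that the two limits leave unreadable from compound 1 to compound 2, swaps similar groups in the opposite sense, and gives no readable size. The other, an at least 2.0-fold lower number from compound 2 to compound 3 (0.30 log units; that floor lies within the scatter), adds the methyl that compound 4 keeps. Neither supports a step beyond the scatter in this assay, so none is expected. The expected step is a 1.1-fold higher number from compound 3 to compound 4 (0.03 log units; within the scatter). Compound 4 is estimated at 25000 nM, with an expected range of 10000 nM to 50000 nM.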

Compound 4, half-maximal cytotoxic concentration: > 49700 nM
Compound 4: no number, only a limit (the forecaster's own chance of this, stated with the estimate: 40%); at least 1.9-fold (0.29 log units) between middle value and limit.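

In this assay, going by these compounds alone, 3,5-difluorophenyl on the saturated chain carbon gives an at least 2.1-fold higher number from compound 3 to compound 4 (0.32 log units; beyond the scatter), the first step here that can be read beyond the scatter. Compound 4 keeps the methyl of compound 3, so that methyl alone does not set the lower number. The size of the step remains a floor, since compound 4 gives only a limit: the limit of > 49700 nM in this assay, at which 1 of the 4 values shown sits.

The steps to compound 4 from compound 1 and from compound 2 cannot be read. On these data alone, what an amine or a carboxylic acid on this carbon would give remains open.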